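The compounds below may be only part of what the source reports. "The series", "measured", "known", "first", "only" and "open" are said of these compounds alone.

Series notes. For the measured compounds named here, compound 2 `O=C(CN1CCN(c2c(Br)cnc3[nH]c(-c4ccccc4)nc23)CC1)Nc1nccs1` gives 3000 nM in a functional assay on HCT-116 cells (Homo sapiens) for inhibition, read by MTT assay, with a stated time of 72 h (on this read-out higher numbers stand for weaker inhibition of growth and lower numbers for stronger inhibition of growth), and stands as the higher of the two numbers so far. Compound 1 `CC(c1ccncc1)N1CCN(c2c(Br)cnc3[nH]c(-c4ccc(N(C)C)cc4)nc23)CC1`, which differs from it in several places, gives 900 nM in this assay. Going by the values given here, no single-change step links those two. Compound 3 `CN(C)c1ccc(-c2nc3c(N4CCN(CC(=O)Nc5nccs5)CC4)c(Br)cnc3[nH]2)cc1` differs from compound 2 by dimethylamino in place of hydrogen on an aromatic carbon. Compound 1 also carries dimethylamino, but its additional differences prevent a direct reading. The step of a 2.0-fold lower number from compound 2 to compound 3 (0.30 log units; within the scatter) is expected to be a modest lowering, near the edge of the scatter. Compound 3 is estimated at 1500 nM, range 500 nM to 5000 nM.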

Compound 3, concentration for 50% growth inhibition: 480 nM
For compound 3 the middle estimate is 3.1-fold (0.49 log units) above the measured one; measured number outside the range, below it.
By their numbers in this assay, from the lowest: compounds 3 and 1 (each within the scatter of the next); then compound 2.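

Dimethylamino on the aromatic carbon para to a large group, the change from phenyl to 4-(dimethylamino)phenyl, gives a 6.3-fold lower number from compound 2 to compound 3 (0.80 log units; beyond the scatter) in this assay and is the only single-place reading at this position. With dimethylamino held, ((1,3-thiazol-2-yl)carbamoyl)methyl in place of 1-(pyridin-4-yl)ethyl on the ring amine nitrogen gives a 1.9-fold lower number from compound 1 to compound 3 (0.27 log units; within the scatter) and so does not separate these two groups. No available evidence bears on the origin of the dimethylamino step.

On these data alone, whether this lowering is specific to dimethylamino stays open, as a methoxy group or a primary amine at this place would show. As far as these compounds go, its size with 1-(pyridin-4-yl)ethyl on the ring nitrogen also stays open.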